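The compounds below may be only part of what the source reports. "The series", "measured", "known", "first", "only" and "open" are said of these compounds alone.

Measured so far:
compound 1, `CC(C)c1cccc(C(C)C)c1OC(=O)NS(=O)(=O)N1CCCC1`: 53000 nM
compound 2, `COc1cc(C(C)(C)C)c(OC(=O)NS(=O)(=O)Nc2c(C(C)C)cccc2C(C)C)c(C(C)(C)C)c1`: 15000 nM

Of the compounds shown here, two have been measured in an assay on liver for inhibition of sterol O-acyltransferase 1 (Rattus norvegicus), using microsomes; on this read-out higher numbers stand for weaker inhibition and lower numbers for stronger inhibition. Compound 1 gives 53000 nM, the highest of the two numbers, which here means the weaker inhibition. Its nearest neighbour is compound 2, which gives 15000 nM, a clearly lower number, and the gap between the two lies beyond the usual scatter of repeated measurements.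

Compound 3, `CC(C)c1cccc(C(C)C)c1OC(=O)NS(=O)(=O)Oc1ccccc1`, has not yet been measured. It differs from compound 1 in one place: phenoxy in place of pyrrolidin-1-yl on a sulfonyl sulfur. Within the data shown here, whether this change helps or hurts is not known from any measured pair, since no two measured compounds differ only here. Among the measured compounds shown here, the sole guide is compound 2, whose value of 15000 nM is the lower of the two. On that thin basis a small step toward stronger inhibition is expected, though a step in the other direction, or none beyond the scatter, would not surprise. Compound 3 is therefore estimated at 30000 nM, with a range from 8000 nM to 120000 nM. For compound 3 the expected step is a 1.8-fold lower number from compound 1 to compound 3 (0.25 log units; within the scatter).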

Compound 3, half-maximal inhibitory concentration: > 50000 nM
Compound 3 gave a limit, no number; the forecaster's own chance of this, stated with the estimate: 15%; middle value at least 1.6-fold (0.22 log units) from the limit.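

Compound 3 gives > 50000 nM and this is a limit of the assay, not a number. Among these compounds, no step from compound 1 to compound 3 can be read from it. The compounds shown leave open whether phenoxy in place of pyrrolidin-1-yl on a sulfonyl sulfur strengthens inhibition, weakens it or leaves it unchanged.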